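Replacing the octyl chain of compound 3 with an ester

The source may report more compounds than this note shows. Statements on the series, on what has been measured and on what is new or still open speak of the compounds shown alone.

Of the compounds shown here, three built on one shared core have been measured in an ADME assay on PC-3 cells (Homo sapiens) for cytotoxicity, read by sulforhodamine B assay, with a stated time of 48 h, tested at 10 uM; a lower number here means less inhibition, a higher number more inhibition at the concentration tested (going by the name of the read-out). Compound 1 `CCCCCCCc1cn(C(c2ccccc2)c2cc3cc(Br)ccc3nc2OC)nn1` gives 4.42%, compound 2 `COc1nc2ccc(Br)cc2cc1C(c1ccccc1)n1cc(-c2ccc(OC(F)(F)F)cc2)nn1` gives 21.6%, and compound 3 `CCCCCCCCc1cn(C(c2ccccc2)c2cc3cc(Br)ccc3nc2OC)nn1` gives 2.27%. Compound 3 thus stands lowest of the three numbers; its nearest neighbour is compound 1, with a number 2.2 percentage points lower from compound 1 to compound 3 (within the scatter), and its furthest is compound 2, with a number 19.3 percentage points lower from compound 2 to compound 3 (beyond the scatter). Among the measured compounds shown here, the one step that clearly rose was a number 17.2 percentage points higher from compound 1 to compound 2 (beyond the scatter).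

Compound 4 `CCOC(=O)c1cn(C(c2ccccc2)c2cc3cc(Br)ccc3nc2OC)nn1` is not yet measured. It differs from compound 3 in one place: ethoxycarbonyl in place of octyl on an aromatic carbon. For the measured compounds named here, no measured step involves an ethoxycarbonyl group, so the bearing of the known steps is indirect. Both alkyl chains, heptyl in compound 1 and octyl in compound 3, gave low numbers, and only the 4-(trifluoromethoxy)phenyl of compound 2 moved the read-out beyond the scatter. The new group is neither an alkyl chain nor an aromatic ring, so the expectation for compound 4 in this assay is a small step, if any, with a modest rise held open: the step from compound 3 is estimated as a number 3.7 percentage points higher from compound 3 to compound 4 (within the scatter). The estimate for compound 4 is therefore 6%, with a range from -4% to 18%.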

Compound 4, a percentage reported as inhibition, at one concentration (the size of the read-out at that concentration, not a potency): 16.1%
For compound 4 the middle estimate is 10.1 percentage points below the measured one; the range from low to high includes it.
By their numbers in this assay, from the lowest: compounds 3 and 1 (each within the scatter of the next); then compounds 4 and 2 (each within the scatter of the next).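

In this assay, this position, an aromatic carbon of a five-membered aromatic ring with 3 nitrogen, now shows that a group other than an aromatic substituent can raise the number clear of the alkyl chains, with a number 13.8 percentage points higher from compound 3 to compound 4 (beyond the scatter) and a number 11.7 percentage points higher from compound 1 to compound 4 (beyond the scatter). The ethoxycarbonyl group has no ring, yet it cannot be told apart from the 4-(trifluoromethoxy)phenyl group, with a number 5.5 percentage points lower from compound 2 to compound 4 (within the scatter), so among these compounds a ring at this place is not needed to reach that level. Nothing available here speaks to why the change from octyl to ethoxycarbonyl has this effect.

Going by these compounds, it remains open which part of the ethoxycarbonyl group goes with the rise: a carboxylic acid, an amide or a methoxycarbonyl group at this place would help to separate the carbonyl from the ethyl part. On these data alone, it is also open whether the step would hold on a changed core, for instance with a chlorine atom in place of the bromine, since all four compounds share the core of compound 1.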